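Methyl on the sulfonyl aryl ring: compound 3 to compound 4

This account rests on a few compounds, and the source may have more. Where it says the series, first, only, none or still open, it means among the compounds named here.

Measured compounds:
compound 1 `Cc1ccc(S(=O)(=O)c2cc3cnc(Nc4ccc5[nH]ccc5c4)nc3n(C)c2=O)cc1` gives 750 nM
compound 2 `Cc1ccc(S(=O)(=O)c2cc3cnc(Nc4ccc5cc[nH]c5c4)nc3n(C)c2=O)cc1` gives 15000 nM
compound 3 `Cn1c(=O)c(S(=O)(=O)c2ccccc2)cc2cnc(Nc3ccc4ncccc4c3)nc21` gives 50000 nM

Of the compounds shown here, three sharing one core have been measured in a functional assay on DU-145 cells (Homo sapiens) for inhibition, read by trypan blue exclusion, with a stated time of 72 h; a lower number here means a stronger inhibitor, a higher number a weaker inhibitor. Compound 3 stands highest of the three numbers; compound 2 comes nearest to it, and compound 1 lies furthest from it. Going by the values given here, the one single-point step among the measured compounds is a 20-fold higher number from compound 1 to compound 2 (1.30 log units; beyond the scatter), which concerns the indolyl group on the ring nitrogen and says nothing about the sulfonyl aryl ring.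

The unmeasured compound 4 `Cc1ccc(S(=O)(=O)c2cc3cnc(Nc4ccc5ncccc5c4)nc3n(C)c2=O)cc1` differs from compound 3 by methyl in place of hydrogen on an aromatic carbon, that is, phenyl to 4-methylphenyl on the sulfonyl. Among the compounds with values here, compounds 1 and 2 carry this 4-methylphenyl, but each also carries a different amine than compound 3, so no measured pair isolates the methyl. Nothing here supports a large move in either direction, and the expected step of a 1.4-fold lower number from compound 3 to compound 4 (0.15 log units; within the scatter) is within the scatter. Compound 4 is therefore estimated at 35000 nM, in the range 12000 nM to 100000 nM.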

Compound 4, half-maximal inhibitory concentration: 10000 nM
For compound 4 the middle estimate is 3.5-fold (0.54 log units) above the measured one, outside the stated range (below it).
By their numbers in this assay, from the lowest: compound 1; then compounds 4 and 2 (each within the scatter of the next); then compound 3.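

In this assay, going by these compounds alone, methyl in place of hydrogen on the sulfonyl aryl ring gives a 5.0-fold lower number from compound 3 to compound 4 (0.70 log units; beyond the scatter) and is the first measured change to isolate this position, showing that the group here affects the read-out even though the step is modest. With the 4-methylphenyl held constant, quinolin-6-yl in place of 1H-indol-6-yl gives a 1.5-fold lower number from compound 2 to compound 4 (0.18 log units; within the scatter) and so does not separate the two groups, whereas quinolin-6-yl in place of 1H-indol-5-yl gives a 13-fold higher number from compound 1 to compound 4 (1.12 log units; beyond the scatter) and leaves 1H-indol-5-yl apart from both. Nothing measured here explains these steps.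

As far as these compounds go, it remains open whether the methyl step would carry over to compounds bearing 1H-indol-5-yl. Also open, from the compounds shown here alone, is how a chlorine, a methoxy group or an ethyl chain would compare with methyl at this place.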